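Compound 1 to compound 3: 4-chlorophenyl to 4-methylphenyl

The source may report more compounds than this note shows. Statements on the series, on what has been measured and on what is new or still open speak of the compounds shown alone.

Of the compounds shown here, two have been measured so far in a functional assay on KYSE-450 cells (Homo sapiens) for inhibition, read by MTT assay, with a stated time of 48 h; a higher number here means a weaker inhibitor, a lower number a stronger inhibitor. Compound 1 (`COc1cc(NCc2ccc(Cl)cc2)cc(OC)c1OC`) reads > 80000 nM, which is a limit of the assay and not a number. Compound 2 (`COc1ccc(CN(C(=O)CCCl)c2cc(OC)c(OC)c(OC)c2)cc1O`) gives 110 nM, a true number, but it differs from compound 1 in more than one place. The pair therefore says nothing about a single change.

The next compound is compound 3 (`COc1cc(NCc2ccc(C)cc2)cc(OC)c1OC`), which keeps the core of compound 1 and carries methyl in place of chloro on an aromatic carbon, para to a large group: methyl in place of chloro on an aromatic carbon.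

Among the measured compounds shown here, no measured step covers this exchange. The expectation rests on compound 1 alone, whose only reading in this assay is the limit > 80000 nM. No step beyond the usual scatter is expected, and no direction is favoured. The expected change is a number no higher from compound 1 to compound 3 (the limit leaves the size open). A second reading at the limit is quite likely. For compound 3 the estimated value is 80000 nM, with an expected range from 25000 nM to 160000 nM.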

Compound 3, half-maximal inhibitory concentration: > 80000 nM
Compound 3 was reported as a limit; the forecaster's own chance of this, stated with the estimate: 70%; the middle value lies on the limit itself.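

No new step can be read from the exchange of chloro for methyl, because compound 1 and compound 3 both stand at a limit of the assay and not at a number: the limit of > 80000 nM in this assay, at which 2 of the 3 values shown sit.

The compounds shown leave open whether chloro and methyl differ at all in this assay, and which of the differences from compound 1 gives compound 2 its 110 nM.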